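The source may report more compounds than this note shows. Statements on the series, on what has been measured and on what is new or still open speak of the compounds shown alone.

Measured so far in a functional assay on PC-12 cells (Rattus norvegicus) for cytotoxicity, read by MTT assay, with stated times of 3 h and 2 h, tested at 20 uM; on this read-out lower numbers stand for a weaker effect and higher numbers for a stronger effect at the one concentration tested:
compound 1 `CC(=O)c1cc2ccc(OCCCn3cc(CNC(=O)CCCCC4CCSS4)nn3)cc2oc1=O` gives 39.8%
compound 2 `CC(=O)c1cc2ccc(OCCCCCn3cc(CNC(=O)CCCCC4CCSS4)nn3)cc2oc1=O` gives 20.7%

Compound 2 stands lowest of the two numbers. Its nearest neighbour, compound 1, gives the higher number, and that gap lies beyond the usual scatter. Compound 3 `O=C(CCCCC1CCSS1)NCc1cn(CCCCCOc2ccc3cc(-c4ccccc4)c(=O)oc3c2)nn1` has not yet been measured in this assay. It differs from compound 2 in one place: phenyl in place of acetyl on an aromatic carbon. Going by the values given here, no pair of measured compounds carries this change, so the measured numbers give no direction for it. The step of a number 1.3 percentage points higher from compound 2 to compound 3 (within the scatter) is expected to stay within the scatter. Compound 3 is estimated at 22% in this assay, within a range of 8% to 40%.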

Compound 3, a percentage reported as activity, at one concentration (the size of the read-out at that concentration, not a potency): 20.7%
Compound 3: the middle estimate sits 1.3 percentage points above what was measured, and the stated range covers the measured number.
By their numbers in this assay, from the lowest: compounds 2 and 3 (each within the scatter of the next); then compound 1.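

In this assay, phenyl in place of acetyl on this aromatic carbon, two atoms from the ring oxygen, gives no change at the digits printed from compound 2 to compound 3 (within the scatter). The position therefore takes a six-membered aromatic ring of carbon only, and loses the acetyl hydrogen-bond acceptor, with no shift beyond the scatter in this one compound pair. No measurement shown gives a reason for this result.

On these data alone, whether the same exchange behaves alike on the shorter linker of compound 1 remains open. So does the read-out with an amine or a carboxylic acid at this position.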